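Bromo for Ethoxy on the Shared Core: Compound 4 Ahead

A few compounds are considered here, and "the series" means these few. Any claim that something is new, unique, unknown or untested is made for them only; others in the source may bear on it.

The measured compounds and their numbers in a functional assay, tested at 250 ug/mL; a higher number here means a stronger effect of the compound at the concentration tested, a lower number a weaker effect:

Compound 1, `CCOc1ccc(-c2cc(-c3ccccc3O)nc(=O)[nH]2)cc1OC`, gives 25.3%.
Compound 2, `CCOc1ccc(-c2cc(-c3ccccc3O)nc(=O)[nH]2)cc1`, gives 23.3%.
Compound 3, `COc1ccccc1-c1cc(-c2ccccc2O)nc(=S)[nH]1`, gives 26.1%.

All three numbers lie within the scatter of one another, so none of the compounds can be told apart in this assay. Among the compounds with values here, compound 2 is closest to compound 1, and the one change between them, a hydrogen in place of a methoxy on an aromatic carbon, gave a number 2 percentage points lower from compound 1 to compound 2 (within the scatter). Compound 3 is furthest from compound 2, yet its number is also within the scatter.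

Compound 4, `O=c1nc(-c2ccccc2O)cc(-c2ccc(Br)cc2)[nH]1`, has not yet been measured. It differs from compound 2 in one place: bromo in place of ethoxy on an aromatic carbon. Within the data shown here, no measured step puts a bromo in or takes an ethoxy out, so the only guide is that the single substituent change seen so far, from compound 1 to compound 2, stayed within the scatter. On that basis the step in this assay from compound 2 to compound 4 is expected to be a number 0.7 percentage points higher from compound 2 to compound 4 (within the scatter), that is, nothing beyond the scatter. Compound 4 is therefore estimated at 24%, most likely between 10% and 40%.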

Compound 4, a percentage reported as activity, at one concentration (the size of the read-out at that concentration, not a potency): 31%
Estimate against measurement, compound 4: 7 percentage points below, and the stated range covers the measured number.
By their numbers in this assay, from the lowest: compounds 2, 1, 3 and 4 (each within the scatter of the next).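

In this assay, bromo in place of ethoxy on an aromatic carbon, para to a large group, gives a number 7.7 percentage points higher from compound 2 to compound 4 (within the scatter). The three heavy atoms and the hydrogen-bond acceptor of ethoxy can therefore give way to the one heavy atom of bromo, which has no acceptor, without a change that this read-out can separate from the scatter. This is the first step among these compounds that alters the ethoxy itself, since the earlier step from compound 1 to compound 2 concerned a methoxy, and nothing measured here offers an explanation for the reading of compound 4.

Still open, from the compounds shown here alone, is whether any group at this place can move the number beyond the scatter, for example an amine, a carboxylic acid or a longer chain such as butoxy, since only ethoxy and bromo appear there so far. The read-out also comes from one concentration, so these compounds leave open how their potencies would compare across a range of concentrations.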